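The source may report more compounds than this note shows. Statements on the series, on what has been measured and on what is new or still open speak of the compounds shown alone.

Going by the values given here, only two compounds of this family have numbers so far in a functional assay on A2780 cells (Homo sapiens) for cytotoxicity, read by MTT assay, with a stated time of 24 h; a lower number here means a stronger inhibitor, a higher number a weaker inhibitor. There compound 1 `CCCCC[C@H](CCC[C@@H]1CC=CC(=O)O1)OC` gives 14400 nM and compound 2 `CCCCC[C@H](C[C@H](O)C[C@@H]1CC=CC(=O)O1)OC` gives 22900 nM. These two values lie within the usual scatter of each other, so compound 1 cannot be ranked against compound 2.

Compound 3 `CCCCC[C@H](CCC[C@H]1CC=CC(=O)O1)OC` has not yet been measured. It relates to compound 1 through configuration alone: the two compounds have the same atoms and bonds and differ only in configuration as drawn: 1 of 2 stereo elements differ; a stereocentre at a saturated ring carbon is drawn R in compound 1 and S in compound 3. The same atoms and bonds are present, and a stereocentre at a saturated ring carbon is drawn R in compound 1 and S in compound 3.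

Among the compounds with values here, the only measured step is a 1.6-fold higher number from compound 1 to compound 2 (0.20 log units; within the scatter). It involves a hydroxy group on a chain carbon, not a configuration at a ring carbon, so it is at best a weak guide. Within the data shown here, no measured pair here tests a change of configuration, which leaves no basis for choosing a direction. The expectation is therefore no shift beyond the scatter, held with a wide margin.

The estimated step is a 1.0-fold higher number from compound 1 to compound 3 (0.02 log units; within the scatter). For compound 3 the expected value is 15000 nM, with an estimated range from 6000 nM to 40000 nM.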

Compound 3, half-maximal inhibitory concentration: 17100 nM
The estimate for compound 3 lay 1.1-fold (0.06 log units) below the measured number; measured number inside the range.
By their numbers in this assay, from the lowest: compounds 1, 3 and 2 (each within the scatter of the next).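

Going by these compounds alone, changing the stereocentre at the saturated ring carbon from R to S is the first change of configuration in this family that can be read, and in this assay it gives a 1.2-fold higher number from compound 1 to compound 3 (0.07 log units; within the scatter). On the chain carried by compound 1, the two drawn configurations at this ring carbon therefore cannot be told apart in this assay, something the earlier step, which concerned a hydroxy group on a chain carbon, could not show. The comparison rests on this single stereocentre, with nothing else in the structure varying: the fact that compounds 1 and 3 differ only in the configuration as drawn.

On these data alone, this result covers one stereocentre on one chain, so the other stereo element remains untested, and it is unknown whether the ring carbon's configuration would also leave the number within the scatter in a compound bearing the chain hydroxy group of compound 2. The compounds shown also leave open how a quite different group on the chain, such as an amine or a carboxylic acid, or a longer chain, would behave in this assay.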